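This account rests on a few compounds, and the source may have more. Where it says the series, first, only, none or still open, it means among the compounds named here.

Of the compounds shown here, three built on one shared core have been tested in a functional assay on HCT-116 cells (Homo sapiens) for antiproliferative activity, read by MTT assay, with a stated time of 48 h; a higher number here means a weaker inhibitor, a lower number a stronger inhibitor. Compound 1 `CCCCCC(CCO)n1cnc2c(OC)ncnc21`, which carries methoxy, gives only a limit, > 50000 nM. Compound 2 `CCCCCC(CCO)n1cnc2c(NC)ncnc21`, which carries methylamino, also gives only a limit, > 50000 nM. Compound 3 `CCCCCC(CCO)n1cnc2c(N(C)C)ncnc21`, which carries dimethylamino, likewise gives only a limit, > 50000 nM. Compound 3 therefore has no exact number and stands at the limit of > 50000 nM in this assay, at which 3 of the 3 values shown sit.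

Compound 4 `CCCCCC(CCO)n1cnc2c(N)ncnc21` has amino in place of dimethylamino on an aromatic carbon. The closest evidence comes from three measured exchanges: a step that the two limits leave unreadable from compound 1 to compound 2, a step that the two limits leave unreadable from compound 1 to compound 3 and a step that the two limits leave unreadable from compound 2 to compound 3. Each joins two limits, so none has a readable size. None of the three compounds reached a true number in this assay, so no clear move in either direction is expected for compound 4, and another limit is the likeliest report. The expected change is a number no higher from compound 3 to compound 4 (the limit leaves the size open). For compound 4 the estimated value is 50000 nM, with an expected range of 25000 nM to 100000 nM.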

Compound 4, half-maximal inhibitory concentration: > 50000 nM
Compound 4: only a limit was reported (the forecaster's own chance of this, stated with the estimate: 75%); the middle value lies on the limit itself.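

The steps joining compound 4 to compound 1, compound 2 and compound 3 cannot be read, because all four compounds stop at a limit: the limit of > 50000 nM in this assay, at which 4 of the 4 values shown sit.

The compounds shown leave open how strong each one truly is, and whether exchanging these groups changes activity at all.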